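Methoxy in place of nitro: an expected small shift

The source may report more compounds than this note shows. Statements on the series, on what has been measured and on what is new or still open speak of the compounds shown alone.

Measured compounds:
compound 1 `Cc1cnc(Nc2ccc([N+](=O)[O-])cc2)nc1Nc1nc2ccccc2s1` — in a functional assay on MCF7 cells (Homo sapiens) for antiproliferative activity, read by MTT assay, with a stated time of 48 h (a higher number here means a weaker inhibitor, a lower number a stronger inhibitor), compound 1 gives > 50000 nM, a limit of the assay rather than a number.
compound 2 `CS(=O)(=O)c1ccc(Nc2nccc(Nc3nc4ccccc4s3)n2)cc1` — compound 2 gives 10600 nM.

Compound 1 stands only at the limit (the limit of > 50000 nM in this assay, at which 1 of the 2 values shown sits), so its place on the scale is not fixed. For the measured compounds named here, compound 2 differs from it in more than one place, so its value shows only that a number was reached there. Compound 3 `COc1ccc(Nc2ncc(C)c(Nc3nc4ccccc4s3)n2)cc1` differs from compound 1 by methoxy in place of nitro on an aromatic carbon. Going by the values given here, no measured step matches this change; compound 3 is expected to move by an at least 1.6-fold lower number from compound 1 to compound 3 (0.22 log units; that floor lies within the scatter) toward stronger inhibition, a step that may not exceed the scatter. Compound 3 is estimated at 30000 nM, between 8000 nM and 60000 nM.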

Compound 3, half-maximal inhibitory concentration: > 50000 nM
Compound 3 ended at the assay's limit; the forecaster's own chance of this, stated with the estimate: 40%; at least 1.6-fold (0.22 log units) between middle value and limit.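

Compound 1 and compound 3 both stand at a limit of the assay, so no step can be read between them: the limit of > 50000 nM in this assay, at which 2 of the 3 values shown sit.

From the compounds shown here alone, what methoxy in place of nitro does in this assay stays open, and so does where either compound lies on the scale.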